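Compound 3: hydroxy to acetoxy on compound 2

The compounds below may be only part of what the source reports. "The series", "measured", "known", "first", "only" and "open" are said of these compounds alone.

In a functional assay on HEp-2 cells (Homo sapiens) for cytotoxicity, read by MTT assay (a lower number here means that less compound is needed, a higher number that more compound is needed for the effect), compound 1 `C=C1C(=O)O[C@]2(C)CC[C@@H]1C[C@H](O)[C@@]1(C)CC[C@H](O1)[C@](C)(O)CC[C@H]2O` gives < 20 ug/mL, a limit of the assay and not a number. Compound 2 `C=C1C(=O)O[C@]2(C)CC[C@@H]1C[C@H](O)[C@@]1(C)CC[C@H](O1)[C@](C)(O)CCC2=O` gives < 20 ug/mL, also a limit and not a number. Compound 2 therefore stands with compound 1 at the limit of < 20 ug/mL in this assay, at which 2 of the 2 values shown sit, and no exact value is known for either.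

Compound 3 `C=C1C(=O)O[C@]2(C)CC[C@@H]1C[C@H](OC(C)=O)[C@@]1(C)CC[C@H](O1)[C@](C)(O)CCC2=O` keeps the core of compound 2 and changes it in one place: acetyl in place of hydrogen on an oxygen on a saturated carbon. This puts acetyl in place of hydrogen on an oxygen on a saturated carbon, turning hydroxy into acetoxy. Among the compounds with values here, no measured pair shows this change. The expectation rests only on compound 2, whose < 20 ug/mL is a limit. The estimated step that the limit leaves unreadable from compound 2 to compound 3 in this assay is expected to stay within the scatter, with no direction favoured. Compound 3 is estimated at 14 ug/mL, with an expected range from 5 ug/mL to 35 ug/mL.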

Compound 3, concentration for half-maximal effect: < 20 ug/mL
Compound 3 gave a limit, no number (the forecaster's own chance of this, stated with the estimate: 65%); the middle value is on the limit's open side.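

No step can be read from compound 2 to compound 3, because both results are limits and not numbers: the limit of < 20 ug/mL in this assay, at which 3 of the 3 values shown sit.

The compounds shown leave open what the exact values in this assay are, and whether turning hydroxy into acetoxy changes the result at all.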